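Acetyl for Hydrogen on an Oxygen: Expecting Compound 4

This account rests on a few compounds, and the source may have more. Where it says the series, first, only, none or still open, it means among the compounds named here.

Compound 1 `COc1cc(C(O)c2ccc3c(ccn3C)c2)cc(OC)c1OC` gives > 1000 nM, a limit of the assay.
Compound 2 `COc1cc(C(OC(C)=O)c2ccc3c(ccn3C)c2)cc(OC)c1OC` gives 260 nM.
Compound 3 `CCn1ccc2cc(/C(=N\O)c3cc(OC)c(OC)c(OC)c3)ccc21` gives > 1000 nM, a limit of the assay.

In a functional assay on HT-29 cells (Homo sapiens) for cytotoxicity, read by XTT assay, with a stated time of 72 h (a higher number here means a weaker inhibitor, a lower number a stronger inhibitor), the measured step is an at least 3.8-fold lower number from compound 1 to compound 2 (0.58 log units; beyond the scatter), made by acetyl in place of hydrogen on an oxygen on a saturated carbon. The difference between the core of compound 1 and the core of compound 3 is not broken down here. Compound 4 `CCn1ccc2cc(/C(=N\OC(C)=O)c3cc(OC)c(OC)c(OC)c3)ccc21` carries the same kind of change on the core of compound 3, (acetyl in place of hydrogen on an oxygen); the place differs, since in compound 1 the oxygen sits on a saturated carbon whose other neighbour is a saturated chain carbon, while in compound 3 the oxygen's other neighbour is a double-bonded nitrogen. From the compounds shown here alone, compound 3 sits at the limit, as does compound 1 (the limit of > 1000 nM in this assay, at which 2 of the 3 values shown sit), so its true value is unknown. Compound 4 is expected to show a step of about an at least 1.6-fold lower number from compound 3 to compound 4 (0.22 log units; that floor lies within the scatter), resting on the measured step of an at least 3.8-fold lower number from compound 1 to compound 2 (0.58 log units; beyond the scatter). The starting point is the limit of compound 3, > 1000 nM. Compound 4 is therefore estimated at 600 nM, expected between 150 nM and 3000 nM.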

Compound 4, half-maximal inhibitory concentration: > 1000 nM
Compound 4: only a limit was reported (the forecaster's own chance of this, stated with the estimate: 35%); at least 1.6-fold (0.22 log units) between middle value and limit.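

No step can be read between compound 3 and compound 4, as both stop at a limit of the assay: the limit of > 1000 nM in this assay, at which 3 of the 4 values shown sit.

From the compounds shown here alone, whether acetyl in place of hydrogen on this oxygen, whose other neighbour is a double-bonded nitrogen, changes the true value remains open.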